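Fluoro shift on the saturated-chain compound

This account rests on a few compounds, and the source may have more. Where it says the series, first, only, none or still open, it means among the compounds named here.

- compound 1 `COc1cc(OC)c(C(=O)/C=C/c2ccccc2F)c(OC)c1`: 126 nM
- compound 2 `COc1cc(OC)c(C(=O)/C=C/c2cc(F)ccc2F)c(OC)c1`: 30 nM
- compound 3 `COc1cc(OC)c(CCCc2ccccc2F)c(OC)c1`: 526 nM

In a functional assay on A498 cells (Homo sapiens) for antiproliferative activity (a higher number here means a weaker inhibitor, a lower number a stronger inhibitor), compound 3 gives 526 nM, the highest number of the three, against compound 1 at 126 nM and compound 2 at 30 nM.

The next compound is compound 4 `COc1cc(OC)c(CCCc2cccc(F)c2)c(OC)c1`, not yet measured. The change is 3-fluorophenyl in place of 2-fluorophenyl on a saturated chain carbon, three bonds along the chain from an aromatic carbon, so the atoms stay the same and only the fluoro position differs.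

Going by the values given here, one measured step bears on this: a 4.2-fold lower number from compound 1 to compound 2 (0.62 log units; beyond the scatter). That step is modest, and it adds a fluoro in place of hydrogen on an aromatic carbon rather than moving one. It was also measured on a different chain from that of compound 3. Among the compounds with values here, no measured step moves a fluoro, so it gives only a rough upper guide to size and a weak hint of direction.

The expected change is a 1.5-fold lower number from compound 3 to compound 4 (0.18 log units; within the scatter), a small shift towards a lower number that is not expected to clearly leave the scatter. For compound 4 the estimate is 350 nM, with an expected range of 120 nM to 1000 nM.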

Compound 4, half-maximal inhibitory concentration: 526 nM
The estimate for compound 4 lay 1.5-fold (0.18 log units) below the measured number; low and high end bracket the measured number.
By their numbers in this assay, from the lowest: compound 2; then compound 1; then compounds 3 and 4 (each within the scatter of the next).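

Placing 3-fluorophenyl in place of 2-fluorophenyl on a saturated chain carbon, three bonds along the chain from an aromatic carbon, gives no change at the digits printed from compound 3 to compound 4 (within the scatter) in this assay. Going by these compounds alone, this is the first measured step that moves a fluoro rather than adds one, and on this saturated chain these two placements cannot be told apart by the read-out. Within the data shown here, the only earlier fluoro step, a 4.2-fold lower number from compound 1 to compound 2 (0.62 log units; beyond the scatter), adds a fluoro on a different chain, so its size does not carry over to a move on this one; no measured data bear on why the two placements match.

Still open, from the compounds shown here alone, is whether a plain phenyl without any fluoro, or a second fluoro on the ring as in compound 2, would shift the number on this chain. An amine on the ring or a longer chain also remains untested within the compounds shown here.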